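This account rests on a few compounds, and the source may have more. Where it says the series, first, only, none or still open, it means among the compounds named here.

Measured compounds in a functional assay on LOX IMVI cells (Homo sapiens) for inhibition, read by sulforhodamine B assay, with a stated time of 48 h; a higher number here means that more compound is tolerated, a lower number that less compound is tolerated:

Compound 1, `Nc1cc(N)c2nc(-c3ccccc3)c(Oc3ccc(Cl)c(Cl)c3)nc2c1`, gives 72400 nM.
Compound 2, `CCOC(=O)[C@H](CCC(=O)O)NC(=O)c1ccc(CNc2nc3cc(N)cc(N)c3nc2-c2ccccc2)cc1`, is reported only as a limit of the assay, < 100000 nM.

Among the measured compounds shown here, compound 1 is the one compound with an actual number in this assay; the other entry is a limit, as recorded in the limit of < 100000 nM in this assay, at which 1 of the 2 values shown sits. The value of compound 1 sits far up the concentration scale, so the cells tolerate a good deal of it before half are killed.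

Compound 3, `Nc1cc(N)c2nc(-c3ccccc3)c(Oc3ccc(F)cc3)nc2c1`, is not yet measured in this assay. It differs from compound 1 by 4-fluorophenyl in place of 3,4-dichlorophenyl on an oxygen on an aromatic ring. For the measured compounds named here, no pair of measured compounds carries this change, so there is no measured step to lean on; the only anchor is compound 1 itself. With a single number and a limit, the working expectation is a step from compound 1 to compound 3 of no more than the usual scatter, if anything toward a higher value: the expected step is a 1.3-fold higher number from compound 1 to compound 3 (0.12 log units; within the scatter). Compound 3 is therefore estimated at 95000 nM, within 40000 nM to 250000 nM, with a fair chance that this assay again returns only a limit.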

Compound 3, concentration lethal to 50% of the cells: < 100000 nM
Compound 3: a limit, no number; the forecaster's own chance of this, stated with the estimate: 40%; the middle value lies beyond the limit too.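

In this assay compound 3 returns only a limit, < 100000 nM. Among the compounds shown here, no step from compound 1 to compound 3 can therefore be read for 4-fluorophenyl in place of 3,4-dichlorophenyl. The compounds shown leave open how far the group on the oxygen shifts the lethal concentration, with compound 1 the only one carrying a number.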